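The source may hold more compounds than are shown below. What is called first, only, known or untested is meant among the compounds shown, and "the series" means these compounds.

Measured in an ADME assay on microsomes from liver (Rattus norvegicus) for metabolic stability, read by LC-MS, using NADPH, with a stated time of 10 min, tested at 0.1 uM; on this read-out higher numbers stand for fast clearance and lower numbers for slow clearance:
- compound 1 `COc1ccc(F)cc1N1C(=O)CSC1c1cccc(C(=O)NCCCCc2ccccc2)c1`: 2300 mL.min-1.g-1
- compound 2 `Cc1cccc(N2C(=O)CSC2c2cccc(C(=O)NCCCCc3ccccc3)c2)c1`: 3140 mL.min-1.g-1
- compound 3 `Cc1ccnc(N2C(=O)CSC2c2cccc(C(=O)NCCCCn3cccn3)c2)c1`: 1020 mL.min-1.g-1

Compound 2 shares the upper end of these numbers with compound 1, and the two lie within the scatter of each other. Among the measured compounds shown here, compound 3 lies lower than compound 2, beyond the scatter, but it differs from compound 2 in more than one place and so gives no clean step.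

The next compound is compound 4 `O=C(NCCCCc1ccccc1)c1cccc(C2SCC(=O)N2c2cccc(-c3c[nH]nn3)c2)c1`. Its change from compound 2 is 1H-1,2,3-triazol-4-yl in place of methyl on an aromatic carbon.

For the measured compounds named here, the only measured step bearing on this is the swap on the same aromatic ring, a 1.4-fold higher number from compound 1 to compound 2 (0.14 log units; within the scatter). That step stayed small, but neither of its compounds carries a group like the one entering here, so it guides the change only weakly. No clear change is therefore expected, with a slight lean to a lower number and wide uncertainty.

The estimated step is a 1.6-fold lower number from compound 2 to compound 4 (0.20 log units; within the scatter).

For compound 4 the expected value is 2000 mL.min-1.g-1, with an estimated range of 800 mL.min-1.g-1 to 4500 mL.min-1.g-1.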

Compound 4, intrinsic clearance in microsomes: 742 mL.min-1.g-1
Compound 4: middle estimate off by 2.7-fold (0.43 log units), on the high side, and the stated range ends above it.
By their numbers in this assay, from the lowest: compounds 4 and 3 (each within the scatter of the next); then compounds 1 and 2 (each within the scatter of the next).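

In this assay, among the compounds shown here, 1H-1,2,3-triazol-4-yl in place of methyl on this aromatic carbon gives the first step beyond the scatter at this position (a 4.2-fold lower number from compound 2 to compound 4 (0.63 log units; beyond the scatter)), whereas the earlier swap on the same ring stayed within it (a 1.4-fold higher number from compound 1 to compound 2 (0.14 log units; within the scatter)). The lower number also holds against the substituted ring of compound 1 (a 3.1-fold lower number from compound 1 to compound 4 (0.49 log units; beyond the scatter)), so this five-membered aromatic ring with 3 hetero atoms sets compound 4 apart from both phenylbutyl amides that lack it. No measurement shown here accounts for the drop.

Open, on these data alone, is whether the step belongs to the triazole itself or would also follow from another group on this carbon, such as a carboxylic acid, an amine or an N-methylated triazole. Also open, as far as these compounds go, is whether the same swap lowers the number when the chain end of compound 3 is present.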